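Replacing the phenyl substituent of compound 3

The source may hold more compounds than are shown below. What is called first, only, known or untested is meant among the compounds shown, and "the series" means these compounds.

- compound 1 `C/C(=N\NC(=O)/C(C#N)=C/c1ccccc1)c1c(O)c2ccc(O)cc2oc1=O` gives 13500 nM in a functional assay on SK-N-SH cells (Homo sapiens) for cytotoxicity, read by MTT assay, with a stated time of 24 h; on this read-out lower numbers stand for stronger inhibition and higher numbers for weaker inhibition
- compound 2 `COc1cc(/C=C(\C#N)C(=O)N/N=C(\C)c2c(O)c3ccc(O)cc3oc2=O)ccc1O` gives 14400 nM
- compound 3 `COc1ccc(/C=C(\C#N)C(=O)N/N=C(\C)c2c(O)c3ccc(O)cc3oc2=O)cc1` gives 9460 nM

Compound 3 does not stand apart from the other two, as the numbers show a 1.4-fold lower number from compound 1 to compound 3 (0.15 log units; within the scatter) and a 1.5-fold lower number from compound 2 to compound 3 (0.18 log units; within the scatter). Compound 4 `C/C(=N\NC(=O)/C(C#N)=C/c1cccc(Br)c1)c1c(O)c2ccc(O)cc2oc1=O` differs from compound 3 in one group (3-bromophenyl in place of 4-methoxyphenyl on a double-bonded chain carbon bound to a double-bonded chain carbon), with 3-bromophenyl in place of 4-methoxyphenyl. The same place was changed in the measured step of a 1.1-fold higher number from compound 1 to compound 2 (0.03 log units; within the scatter), which also stays within the scatter. Going by the values given here, no measured compound carries bromine, so this evidence is indirect. No step beyond the scatter is therefore expected in this assay. The expected step is a 1.1-fold higher number from compound 3 to compound 4 (0.02 log units; within the scatter). For compound 4 the estimated value is 10000 nM, with an expected range from 5000 nM to 20000 nM.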

Compound 4, half-maximal inhibitory concentration: 31300 nM
Estimate against measurement, compound 4: 3.1-fold (0.50 log units) below; measured number above the stated range.
By their numbers in this assay, from the lowest: compounds 3, 1 and 2 (each within the scatter of the next); then compound 4.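

In this assay, this place on the double-bonded chain carbon proves sensitive to the ring it carries, which the earlier swaps did not show: 3-bromophenyl gives a 3.3-fold higher number from compound 3 to compound 4 (0.52 log units; beyond the scatter) and a 2.2-fold higher number from compound 2 to compound 4 (0.34 log units; beyond the scatter). The plainest comparison is bromo in place of hydrogen on an aromatic carbon, which gives a 2.3-fold higher number from compound 1 to compound 4 (0.37 log units; beyond the scatter). No measurement here accounts for this weaker result. Still open, from the compounds shown here alone, is whether the loss follows bromine itself or extends to other atoms, and how a phenyl carrying an amine or a carboxylic acid would behave.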